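Replacing hydroxy with dimethylamino on compound 3

The compounds below may be only part of what the source reports. "The series", "measured", "known", "first", "only" and "open" are said of these compounds alone.

In an in vitro ADME assay on microsomes from liver (Rattus norvegicus) for metabolic stability (a lower number here means that the compound disappears faster, a higher number that the compound lasts longer), three compounds with a shared core differ in one group on an aromatic carbon. Compound 1 `CC(O)c1ccc2c(NCc3ccc(NC(=O)c4ccc(F)cc4)cc3)nc(N(C)C)nc2c1` has a half-life of 0.1 h and compound 2 `CN(C)c1nc(NCc2ccc(NC(=O)c3ccc(F)cc3)cc2)c2ccc(C=O)cc2n1` has one of 0.05 h while compound 3 `CN(C)c1nc(NCc2ccc(NC(=O)c3ccc(F)cc3)cc2)c2ccc(CO)cc2n1` reaches 0.367 h as the highest of the three. Compound 4 `CN(C)Cc1ccc2c(NCc3ccc(NC(=O)c4ccc(F)cc4)cc3)nc(N(C)C)nc2c1` carries dimethylamino in place of hydroxy on a saturated chain carbon bound to an aromatic carbon and so turns hydroxymethyl into (dimethylamino)methyl. Among the compounds with values here, two measured steps touch this same group: a 7.3-fold higher number from compound 2 to compound 3 (0.87 log units; beyond the scatter) for hydroxymethyl in place of formyl and a 3.7-fold higher number from compound 1 to compound 3 (0.56 log units; beyond the scatter) for hydrogen in place of methyl. Both are modest but beyond the scatter. Neither replaces the hydroxy itself, so neither measures this change directly. Compound 3 at 0.367 h stands above both other compounds, so a small drop seems the likelier outcome. The expected step is a 1.8-fold lower number from compound 3 to compound 4 (0.26 log units; within the scatter) in this assay and it is small and downward. For compound 4 the estimate is 0.2 h with an expected range from 0.07 h to 0.5 h as its half-life.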

Compound 4, half-life in the Rattus norvegicus assay: 0.05 h
The estimate for compound 4 lay 4.0-fold (0.60 log units) above the measured number; the measured number lies below the stated range.
By their numbers in the Rattus norvegicus assay, from the lowest: compounds 2, 4 and 1 (each within the scatter of the next); then compound 3.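

In the Rattus norvegicus assay, replacing the hydroxy itself gives a 7.3-fold lower number from compound 3 to compound 4 (0.87 log units; beyond the scatter), so the higher half-life of compound 3 does not survive this change at this position. Within the data shown here, in the Rattus norvegicus assay, (dimethylamino)methyl also gives no change at the digits printed from compound 2 to compound 4 (within the scatter) against formyl and a 2.0-fold lower number from compound 1 to compound 4 (0.30 log units; within the scatter) against 1-hydroxyethyl, which leaves the hydroxymethyl of compound 3 as the only group here that stands apart from the other three. In a physicochemical assay for solubility, at pH 7.4 (a higher number here means a more soluble compound, a lower number a less soluble compound), compound 3 gives 4 ug/mL and compound 4 gives 55 ug/mL, so the same change goes the other way, and by a wide margin: the measured solubility of compound 3, 4 ug/mL, and of compound 4, 55 ug/mL, a 14-fold higher number (1.14 log units; beyond the scatter)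

The compounds shown cannot tell whether the shorter half-life goes with the arrival of dimethylamino or with the loss of hydroxy. A methoxy group or a primary amine on this saturated chain carbon would help separate those two readings, and would test whether the gain in solubility comes with them.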